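Shifting the pyridine nitrogen in a cytotoxicity series

The source may hold more compounds than are shown below. What is called first, only, known or untested is meant among the compounds shown, and "the series" means these compounds.

The measured compounds and their values in an ADME assay on Vero cells (Chlorocebus sabaeus) for cytotoxicity; on this read-out lower numbers stand for higher toxicity in this test and higher numbers for lower toxicity in this test:
Compound 1, `NC(=O)c1cccc2[nH]c(-c3cccnc3)nc12`, gives 77.7 uM.
Compound 2, `O=C(NCCO)c1cccc2[nH]c(-c3cccnc3)nc12`, gives 682 uM.
Compound 3, `O=C(Nc1ccccc1)c1cccc2[nH]c(-c3cccnc3)nc12`, gives 34.2 uM.

Compound 3 gives the lowest number of the three in this assay; compound 1 is nearest, and compound 2 is furthest. The two steps into compound 3 are both on the amide-type nitrogen: a 2.3-fold lower number from compound 1 to compound 3 (0.36 log units; beyond the scatter) and a 20-fold lower number from compound 2 to compound 3 (1.30 log units; beyond the scatter). The third step, an 8.8-fold higher number from compound 1 to compound 2 (0.94 log units; beyond the scatter), also concerns that nitrogen.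

Compound 4, `O=C(Nc1ccccc1)c1cccc2[nH]c(-c3ccncc3)nc12`, differs from compound 3 in a single place: pyridin-4-yl in place of pyridin-3-yl on an aromatic carbon. Among the measured compounds shown here, none of the measured steps touches this position; all three change the substituent on the amide-type nitrogen, so they give no direct guide to what a shift of the pyridine nitrogen does in this assay. For the measured compounds named here, with no step bearing on the change, the most reasonable expectation is no step beyond the scatter, in either direction.

Compound 4 is therefore expected to give about 34 uM in this assay, within a range of 15 uM to 80 uM. This corresponds to an expected step of a 1.0-fold lower number from compound 3 to compound 4 (0.00 log units; within the scatter).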

Compound 4, half-maximal toxic concentration: 49.8 uM
For compound 4 the middle estimate is 1.5-fold (0.17 log units) below the measured one; the measured number falls inside the stated range.
By their numbers in this assay, from the lowest: compounds 3, 4 and 1 (each within the scatter of the next, the first and the last beyond it); then compound 2.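

In this assay the swap of pyridin-3-yl for pyridin-4-yl, on the aromatic carbon between two ring nitrogen atoms, gives a 1.5-fold higher number from compound 3 to compound 4 (0.16 log units; within the scatter) and so leaves the two compounds indistinguishable in this test, at least with phenyl on the amide-type nitrogen. Among the compounds shown here, this is the first reading at this position, since the earlier compounds varied only the amide-type nitrogen, where steps such as a 20-fold lower number from compound 2 to compound 3 (1.30 log units; beyond the scatter) lie well beyond the scatter; the placing of the pyridine nitrogen, in these two isomers, shows no such effect. Nothing available explains why the two isomers read alike.

Going by these compounds, the swap is seen only alongside phenyl on the amide-type nitrogen, so it remains open whether pyridin-4-yl would read the same with the unsubstituted amide of compound 1 or the 2-hydroxyethyl amide of compound 2. Also open, on these data alone, is what pyridin-2-yl, a plain phenyl ring or a pyridine carrying an amine would give on this carbon in this assay and whether any of them would step beyond the scatter.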